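Third Aryl Fluorine and Plasma Protein Binding Outlook

The source may hold more compounds than are shown below. What is called first, only, known or untested is meant among the compounds shown, and "the series" means these compounds.

Three compounds have been measured in an ADME assay on a cell-free system (plasma, Rattus norvegicus) for protein binding; a lower number here means a smaller unbound share, a higher number a larger unbound share of the compound:

- Compound 1 `COc1ccc(F)cc1C1CCN(c2ccn3c(CC(F)(F)F)nnc3c2Cl)CC1` gives < 0.01, a limit of the assay rather than a number.
- Compound 2 `COc1ccc(F)cc1C1CCN(c2ccn3c(CC4CC4)nnc3c2Cl)CC1` gives < 0.01, again a limit of the assay.
- Compound 3 `COc1cccc(F)c1C1CCN(c2ccn3c(CC4CC4)nnc3c2Cl)CC1` gives < 0.01, also a limit of the assay.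

Compound 2 therefore stands only at a limit in this assay, with no numeric value to anchor it, and the same holds for its two neighbours, as summed up by the limit of < 0.01 in this assay, at which 3 of the 3 values shown sit. The two measured steps that touch compound 2 are a step that the two limits leave unreadable from compound 1 to compound 2 and a step that the two limits leave unreadable from compound 2 to compound 3; neither can be sized, so they tell nothing about how a change at the saturated ring carbon shifts the unbound share.

Compound 4 `COc1c(F)ccc(F)c1C1CCN(c2ccn3c(CC4CC4)nnc3c2Cl)CC1` differs from compound 2 by 3,6-difluoro-2-methoxyphenyl in place of 5-fluoro-2-methoxyphenyl on a saturated ring carbon. Among the compounds with values here, the only step that changes the same aryl group, from compound 2 to compound 3, is unreadable, and no measured step bears on adding a fluorine to this ring. The expectation is therefore that compound 4 stays at the limit, with an expected step that the limit leaves unreadable from compound 2 to compound 4 that cannot be read. The estimate for compound 4 in this assay is 0.005, expected to lie between 0.001 and 0.012, most likely reported again as a limit.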

Compound 4, unbound fraction: < 0.01
Compound 4: only a limit was reported (the forecaster's own chance of this, stated with the estimate: 85%); the middle value does not contradict the limit.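

Compound 4 adds no readable step against compound 2 or compound 3 in this assay, because each comparison sets one limit of the assay against another: the limit of < 0.01 in this assay, at which 4 of the 4 values shown sit.

The compounds shown leave open how large the unbound share of each one is, and whether the 3,6-difluoro-2-methoxyphenyl group changes it at all.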